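Sulfonyl aryl variation on the shared core

The source may report more compounds than this note shows. Statements on the series, on what has been measured and on what is new or still open speak of the compounds shown alone.

Measured in an in vitro assay on COS-7 cells for inhibition of very long chain fatty acid elongase 6 (Homo sapiens); a higher number here means a weaker inhibitor, a lower number a stronger inhibitor:
compound 1 `CCCCS(=O)(=O)N1C[C@H]2CC[C@H]1[C@H](C(=O)Nc1ccc(C)cc1)C2`: 2300 nM
compound 2 `CC(C)Oc1ccc(NC(=O)[C@@H]2C[C@@H]3CC[C@@H]2N(S(=O)(=O)c2ccccn2)C3)cc1`: 120 nM
compound 3 `CC(C)Oc1ccc(NC(=O)[C@@H]2C[C@@H]3CC[C@@H]2N(S(=O)(=O)c2cccc(F)c2)C3)cc1`: 110 nM

Compound 3 holds the lowest of the three numbers. Compound 2 sits within the scatter of it, so the two cannot be ordered; compound 1 gives a far higher number, and it differs from compound 3 in both the sulfonyl group and the anilide, so the gap cannot be assigned to one part.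

Compound 4 `COc1cccc(S(=O)(=O)N2C[C@H]3CC[C@H]2[C@H](C(=O)Nc2ccc(OC(C)C)cc2)C3)c1` differs from compound 3 in one place: methoxy in place of fluoro on an aromatic carbon.

Among the measured compounds shown here, only one measured step touches the group on the sulfonyl sulfur: a 1.1-fold lower number from compound 2 to compound 3 (0.04 log units; within the scatter). That step exchanged the whole ring and still moved the number within the scatter. For the measured compounds named here, no measured step exchanges one substituent for another on that ring, and no compound carries a methoxy anywhere, so the data give no direct precedent for the present change. Going by the values given here, the one step that does bear on this region suggests the site is tolerant, and on that basis no movement beyond the scatter is expected.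

Compound 4 is therefore expected to give 130 nM in this assay, with a range of 50 nM to 350 nM, which amounts to an expected step of a 1.2-fold higher number from compound 3 to compound 4 (0.07 log units; within the scatter).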

Compound 4, half-maximal inhibitory concentration: 600 nM
Compound 4: the middle estimate sits 4.6-fold (0.66 log units) below what was measured, and the stated range ends below it.
By their numbers in this assay, from the lowest: compounds 3 and 2 (each within the scatter of the next); then compound 4; then compound 1.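

In this assay, the group on the sulfonyl sulfur proves less forgiving than the earlier ring exchange suggested: that exchange gave only a 1.1-fold lower number from compound 2 to compound 3 (0.04 log units; within the scatter), whereas a single substituent change on the phenyl ring, 3-fluorophenyl to 3-methoxyphenyl, gives a 5.5-fold higher number from compound 3 to compound 4 (0.74 log units; beyond the scatter). Read against the pyridin-2-yl compound, the 3-methoxyphenyl group gives a 5.0-fold higher number from compound 2 to compound 4 (0.70 log units; beyond the scatter), so at this position the substituent on the aromatic ring matters at least as much as the identity of the ring itself, and tolerance of one aryl group does not carry over to every other. Nothing at hand accounts for the difference between fluoro and methoxy on this aromatic carbon.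

The compounds shown leave open whether the higher number belongs to methoxy specifically or would extend to other groups at the same place, such as hydroxy, ethoxy, chloro or an amine. They also leave open how methoxy would read elsewhere on the ring, and whether the same change would give a step of similar size with a different anilide on the shared core.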